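The compounds below may be only part of what the source reports. "The series", "measured", "known", "first", "only" and "open" are said of these compounds alone.

Values so far in an ADME assay (on this read-out lower numbers stand for a shorter-lived compound and higher numbers for a longer-lived compound), are as follows
- compound 1 `COc1ccc(C[S+]([O-])c2ncccc2C(=O)Nc2ccncc2)c(OC)c1` gives < 0.02 h
- compound 2 `COc1cc(OC)c(OC)cc1C[S+]([O-])c1ncccc1C(=O)Nc1ccncc1` gives < 0.02 h
- compound 3 `COc1cc(OC)c(C[S+]([O-])c2ncccc2C(=O)Nc2ccncc2)c(OC)c1` gives < 0.02 h

Compound 1 stands at < 0.02 h and that is a limit, not a number. Among the measured compounds shown here, the whole measured set sits at the limit of < 0.02 h in this assay, at which 3 of the 3 values shown sit, and no measured compound has yet given a number.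

Compound 4 `COCOc1cc(OC)ccc1C[S+]([O-])c1ncccc1C(=O)Nc1ccncc1` differs from compound 1 as follows methoxy in place of hydrogen on a saturated chain carbon bound to an oxygen on an aromatic ring and this reads as methoxy in place of hydrogen on a saturated chain carbon bound to an oxygen on an aromatic ring, that is, methoxy to methoxymethoxy.

The nearest measured changes put methoxy on an aromatic carbon instead, and a step that the two limits leave unreadable from compound 1 to compound 2 is joined by a step that the two limits leave unreadable from compound 1 to compound 3 in giving no size to carry over. No step beyond the scatter is therefore expected in this assay and no direction can be expected either. The estimated outcome is a step that the limit leaves unreadable from compound 1 to compound 4 and a report of only a limit is the likely result. Compound 4 is estimated at 0.015 h with an expected range from 0.007 h to 0.03 h in this read-out.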

Compound 4, half-life: < 0.02 h
Compound 4: no number, only a limit; the forecaster's own chance of this, stated with the estimate: 85%; the middle value lies beyond the limit too.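

In this assay compound 4 returns only a limit, as compound 1 does, so no step can be read between compound 1 and compound 4. The size and direction of the change from methoxy to methoxymethoxy stay open, as does whether any compound here can give a number rather than a limit: the limit of < 0.02 h in this assay, at which 4 of the 4 values shown sit.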